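The source may report more compounds than this note shows. Statements on the series, on what has been measured and on what is new or still open speak of the compounds shown alone.

Measured in a functional assay on HCT-116 cells (Homo sapiens), read by sulforhodamine B assay, with a stated time of 5 days; a lower number here means a stronger inhibitor of growth, a higher number a weaker inhibitor of growth:
Compound 1 `OC[C@H]1O[C@@H](n2cc(F)c3c(-c4ccco4)ncnc32)[C@H](O)[C@@H]1O`: 39 nM
Compound 2 `OC[C@H]1O[C@@H](n2cc(Cl)c3c(-c4ccccc4)ncnc32)[C@H](O)[C@@H]1O`: 1400 nM

Compound 2 has the higher of the two numbers, so it is the weaker inhibitor of growth. Compound 3 `OC[C@H]1O[C@@H](n2cc(Cl)c3c(-c4ccco4)ncnc32)[C@H](O)[C@@H]1O` has furan-2-yl in place of phenyl on an aromatic carbon of compound 2: furan-2-yl in place of phenyl on an aromatic carbon. Within the data shown here, the measured pair differs in more than one place, so no measured step isolates this swap. Still, compound 1 also carries furan-2-yl and gives 39 nM, which points to a large fall. The expected step is a 23-fold lower number from compound 2 to compound 3 (1.37 log units; beyond the scatter), beyond the scatter and towards stronger inhibition. The estimate for compound 3 is 60 nM, with an expected range of 15 nM to 250 nM.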

Compound 3, concentration for 50% growth inhibition: > 10000 nM
Compound 3 gave a limit, no number; the forecaster's own chance of this, stated with the estimate: 1%; middle value at least 160-fold (2.22 log units) away from the limit.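

In this assay compound 3 stands at a limit of the assay and has no exact number: the limit of > 10000 nM in this assay, at which 1 of the 3 values shown sits. Furan-2-yl on this aromatic carbon therefore does not bring strong inhibition of growth by itself, since putting it in place of phenyl gives an at least 7.1-fold higher number from compound 2 to compound 3 (0.85 log units; beyond the scatter) with chloro kept. With furan-2-yl kept, chloro in place of fluoro gives an at least 250-fold higher number from compound 1 to compound 3 (2.40 log units; beyond the scatter) and so decides much of the outcome. As far as these compounds go, whether furan-2-yl would still beat or trail phenyl with fluoro present stays open. From the compounds shown here alone, what an amine on this aromatic carbon would give is also open.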